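The source may report more compounds than this note shows. Statements on the series, on what has been measured and on what is new or still open speak of the compounds shown alone.

Compound 2 `COc1ccc(N2CCN(C(=S)SCc3nc4cc(Cl)c(Cl)cc4[nH]3)CC2)cc1` gives 19900 nM in a functional assay on MCF7 cells (Homo sapiens) for cytotoxicity, read by MTT assay, with a stated time of 24 h; on this read-out lower numbers stand for stronger inhibition and higher numbers for weaker inhibition. The other member measured is compound 1 `CN1CCN(C(=S)SCc2nc3cc(Cl)c(Cl)cc3[nH]2)CC1`, and in this assay compound 1 gives 30500 nM; the two values lie within the scatter of each other: a 1.5-fold lower number from compound 1 to compound 2 (0.19 log units; within the scatter). Compound 3 `S=C(SCc1nc2cc(Cl)c(Cl)cc2[nH]1)N1CCN(c2ccccc2Cl)CC1` carries 2-chlorophenyl in place of 4-methoxyphenyl on an amine nitrogen in a ring. Going by the values given here, the one measured step bearing on this place, an exchange of the group on the same ring nitrogen, stayed within the scatter, and no other comparison is available. Accordingly the expected step in this assay is a 1.0-fold higher number from compound 2 to compound 3 (0.00 log units; within the scatter), within the scatter. Compound 3 is estimated at 20000 nM, between 8000 nM and 50000 nM.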

Compound 3, half-maximal inhibitory concentration: 60200 nM
Estimate against measurement, compound 3: 3.0-fold (0.48 log units) below, outside the stated range (above it).
By their numbers in this assay, from the lowest: compounds 2, 1 and 3 (each within the scatter of the next, the first and the last beyond it).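

In this assay, going by these compounds alone, the group on this ring nitrogen now makes a difference: a 3.0-fold higher number from compound 2 to compound 3 (0.48 log units; beyond the scatter) is the first step here beyond the scatter, whereas the earlier exchange stayed within it. The 2-chlorophenyl group remains within the scatter of methyl (a 2.0-fold higher number from compound 1 to compound 3 (0.30 log units; within the scatter)), so the two substituted phenyl groups separate from each other while neither separates from methyl. No measured evidence bears on the reason for this result. Still open, going by these compounds, is how unsubstituted phenyl or 4-chlorophenyl would read here, which would show whether the identity of the substituent or its ring location accompanies the gap.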